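Swapping Bromo for Trifluoromethyl on a Shared Core

The source may report more compounds than this note shows. Statements on the series, on what has been measured and on what is new or still open speak of the compounds shown alone.

For the measured compounds named here, compound 2 `O=c1cc(-n2cc(COc3ccc(Br)cc3)nn2)c2cc(Br)ccc2o1` gives 24500 nM in a functional assay on A549 cells (Homo sapiens) for antiproliferative activity, read by MTT assay, with a stated time of 48 h (on this read-out higher numbers stand for weaker inhibition and lower numbers for stronger inhibition), one of only two numbers so far. Compound 1 `O=c1cc(-n2cc(COc3ccccc3)nn2)c2cc(Br)ccc2o1` gives 12300 nM, and the step of a 2.0-fold higher number from compound 1 to compound 2 (0.30 log units; within the scatter) lies within the scatter. Compound 3 `O=c1cc(-n2cc(COc3ccc(C(F)(F)F)cc3)nn2)c2cc(Br)ccc2o1` differs from compound 2 by trifluoromethyl in place of bromo on an aromatic carbon. Going by the values given here, no measured step exchanges bromo for trifluoromethyl; the only guide is that placing bromo at this position changed little. Compound 3 is therefore expected to give roughly the same number, about 20000 nM, likely between 8000 nM and 50000 nM. The expected step of a 1.2-fold lower number from compound 2 to compound 3 (0.09 log units; within the scatter) is small.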

Compound 3, half-maximal inhibitory concentration: 1620 nM
The estimate for compound 3 lay 12-fold (1.09 log units) above the measured number; measured number below the stated range.
By their numbers in this assay, from the lowest: compound 3; then compounds 1 and 2 (each within the scatter of the next).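

In this assay this position proves sensitive to the group it carries: trifluoromethyl gives a 7.6-fold lower number from compound 1 to compound 3 (0.88 log units; beyond the scatter) and, set against bromo, a 15-fold lower number from compound 2 to compound 3 (1.18 log units; beyond the scatter) even though bromo itself shifted the number only within the scatter. Filling the position is therefore not enough, and the identity of the group decides the outcome. Nothing available explains why these two groups differ.

From the compounds shown here alone, whether an amine, a carboxylic acid or a methoxy group here would behave like trifluoromethyl or like bromo remains open. So does whether trifluoromethyl would have the same effect elsewhere on this ring.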